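A few compounds are considered here, and "the series" means these few. Any claim that something is new, unique, unknown or untested is made for them only; others in the source may bear on it.

In a physicochemical assay for solubility (a higher number here means a more soluble compound, a lower number a less soluble compound), the measured compounds read:

Compound 1 `CC(C)C(=O)N1CCC[C@H]1C(=O)N1CCC(NS(=O)(=O)c2cc(S(=O)(=O)c3ccccc3)ccc2C(F)(F)F)CC1`: 100000 nM
Compound 2 `CN(C)c1ccc(C(=O)N2CCC[C@H]2C(=O)N2CCC(NS(=O)(=O)c3cc(S(=O)(=O)c4ccccc4)ccc3C(F)(F)F)CC2)cc1`: 100000 nM

Compound 2 stands level with compound 1 at the digits reported, so the two compounds give no order. The next structure is compound 3 `CC(C)(C)CCN1CCC[C@H]1C(=O)N1CCC(NS(=O)(=O)c2cc(S(=O)(=O)c3ccccc3)ccc2C(F)(F)F)CC1`. The change is 3,3-dimethylbutyl in place of (4-(dimethylamino)phenyl)carbonyl on an amine nitrogen in a ring. Among the compounds with values here, only one measured step bears on this, and it does so only in part. Within the data shown here, that step, no change at the digits printed from compound 1 to compound 2 (within the scatter), exchanged isopropyl for 4-(dimethylamino)phenyl on a carbonyl carbon, whereas compound 3 loses the carbonyl as well, a change no measured compound shows. On this thin evidence, no shift beyond the scatter is expected in this assay, in either direction. The expected step is no change at the digits printed from compound 2 to compound 3 (within the scatter). Compound 3 is estimated at 100000 nM, with an expected range of 50000 nM to 120000 nM.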

Compound 3, solubility: 12500 nM
The estimate for compound 3 lay 8.0-fold (0.90 log units) above the measured number; the whole stated range lies above it.
By their numbers in this assay, from the lowest: compound 3; then compounds 1 and 2 (each within the scatter of the next).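

In this assay, the group on the amine nitrogen in the ring proves able to move the number, which the earlier exchange on the carbonyl carbon did not. Putting 3,3-dimethylbutyl in place of (4-(dimethylamino)phenyl)carbonyl gives an 8.0-fold lower number from compound 2 to compound 3 (0.90 log units; beyond the scatter), and putting it in place of isopropylcarbonyl gives an 8.0-fold lower number from compound 1 to compound 3 (0.90 log units; beyond the scatter), so the same drop appears from both carbonyl-bearing compounds. No measurement shown here accounts for this drop.

Each step removes the carbonyl and changes the carbon group at once, so the compounds shown do not separate the two. Also open, on these data alone, is whether a chain ending in an amine or a carboxylic acid on this nitrogen, or an acyl group carrying the same 3,3-dimethylbutyl skeleton, would stay near compound 3 or return toward compound 1.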